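This account rests on a few compounds, and the source may have more. Where it says the series, first, only, none or still open, it means among the compounds named here.

In a functional assay on MGC-803 cells (Homo sapiens) for cytotoxicity, read by MTT assay, with a stated time of 72 h (a higher number here means a weaker inhibitor, a lower number a stronger inhibitor), compound 1 `CCCCCCCCNc1nc(SCc2ccc(C(F)(F)F)cc2)nc2ccccc12` gives 12600 nM. Compound 3 `FC(F)(F)c1ccc(CSc2nc(Nc3cccc(C(F)(F)F)c3)c3ccccc3n2)cc1` gives 15100 nM in this assay, and the step of a 1.2-fold higher number from compound 1 to compound 3 (0.08 log units; within the scatter) lies within the scatter, so these two numbers cannot be told apart. Compound 2 `COc1ccccc1Nc1nc(SCc2ccc(C(F)(F)F)cc2)nc2ccccc12` reaches only a limit of the assay, > 50000 nM, which is one of the values shown (the limit of > 50000 nM in this assay, at which 1 of the 3 values shown sits).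

Compound 4 `O=[N+]([O-])c1ccc(Nc2nc(SCc3ccc(C(F)(F)F)cc3)nc3ccccc23)cc1` has not yet been measured. It differs from compound 3 in one place: 4-nitrophenyl in place of 3-(trifluoromethyl)phenyl on a nitrogen on an aromatic ring. Among the compounds with values here, two measured steps bear on this change. The step of an at least 3.3-fold lower number from compound 2 to compound 3 (0.51 log units; beyond the scatter) shows that exchanging one aromatic group for another on that nitrogen can move the number beyond the scatter. The step of a 1.2-fold higher number from compound 1 to compound 3 (0.08 log units; within the scatter) shows that putting an aromatic group in place of the octyl chain left the number within the scatter. Neither step involves a nitrophenyl group, so the direction for compound 4 cannot be read from them. The expected step of a 1.1-fold higher number from compound 3 to compound 4 (0.03 log units; within the scatter) is therefore small, within the scatter or at most modest in either direction. Compound 4 is estimated at 16000 nM, with a range from 5000 nM to 50000 nM.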

Compound 4, half-maximal inhibitory concentration: 8170 nM
The estimate for compound 4 lay 2.0-fold (0.29 log units) above the measured number, within the range that was stated.
By their numbers in this assay, from the lowest: compounds 4, 1 and 3 (each within the scatter of the next). At a limit, above all of these: compound 2.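

In this assay, the exchange on the nitrogen gives a 1.8-fold lower number from compound 3 to compound 4 (0.27 log units; within the scatter), and replacing the chain gives a 1.5-fold lower number from compound 1 to compound 4 (0.19 log units; within the scatter), so the 4-nitrophenyl, 3-(trifluoromethyl)phenyl and octyl groups cannot be told apart at this position. Within the data shown here, the one step beyond the scatter that the new result adds is an at least 6.1-fold lower number from compound 2 to compound 4 (0.78 log units; beyond the scatter), which shows that the 4-nitrophenyl group, like the 3-(trifluoromethyl)phenyl group before it, stands clear of the 2-methoxyphenyl group. That step starts from compound 2, whose value is a limit of the assay and not a number: the limit of > 50000 nM in this assay, at which 1 of the 4 values shown sits.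

The compounds shown leave open whether compound 2 stands apart through the methoxy group itself or through where that group sits on the ring, as neither a 4-methoxyphenyl nor a 2-nitrophenyl group is among them. Also open, on these data alone, is how a plain phenyl group, a shorter chain, an amine or a carboxylic acid would read at this position in this assay, and whether any group on this nitrogen can move the number well below those of compound 1, compound 3 and compound 4.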